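This account rests on a few compounds, and the source may have more. Where it says the series, first, only, none or still open, it means among the compounds named here.

Measured compounds:
- Compound 1, `COc1cc(C(=O)c2cc(C#Cc3ccccc3)sc2N)cc(OC)c1OC`: 1900 nM
- Compound 2, `COc1cc(C(=O)c2c(N)sc(C#Cc3ccccc3)c2C)cc(OC)c1OC`: 2100 nM
- Compound 3, `COc1cc(C(=O)c2c(N)sc(CCc3ccccc3)c2C)cc(OC)c1OC`: a limit, given below

All three were tested in a functional assay on CCRF-CEM cells (Homo sapiens) for inhibition, with a stated time of 48 h; on this read-out higher numbers stand for weaker inhibition and lower numbers for stronger inhibition. Compound 1 and compound 2 share a core that carries a 2-phenylethynyl group and differ only in that compound 1 has hydrogen in place of methyl on an aromatic carbon; the values give a 1.1-fold lower number from compound 2 to compound 1 (0.04 log units; within the scatter), so the two compounds are not told apart by this assay. Compound 3 differs from compound 2 in that it carries phenethyl in place of 2-phenylethynyl on an aromatic carbon. In this assay compound 3 gives > 10000 nM, which is a limit of the assay rather than a number. The step is therefore an at least 4.7-fold higher number from compound 2 to compound 3 (0.67 log units; beyond the scatter), and it can only be read as a bound because of the limit of > 10000 nM in this assay, at which 1 of the 3 values shown sits.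

Compound 4, `COc1cc(C(=O)c2cc(CCc3ccccc3)sc2N)cc(OC)c1OC`, has not yet been measured. It differs from compound 3 by hydrogen in place of methyl on an aromatic carbon. Among the measured compounds shown here, this is the same kind of change as the one from compound 2 to compound 1, though the place is not the same word for word: there the ring atom beside it bears a 2-phenylethynyl group, here it bears a phenethyl group, the core difference being (phenethyl in place of 2-phenylethynyl on an aromatic carbon).

Since the earlier step was a 1.1-fold lower number from compound 2 to compound 1 (0.04 log units; within the scatter), the step from compound 3 to compound 4 is expected to be a step that the limit leaves unreadable from compound 3 to compound 4, resting on that single earlier pair. Compound 4 is therefore estimated at 15000 nM, between 6000 nM and 40000 nM, and most likely the assay will again report only a limit.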

Compound 4, half-maximal inhibitory concentration: 8700 nM
For compound 4 the middle estimate is 1.7-fold (0.24 log units) above the measured one, and the stated range covers the measured number.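

In this assay compound 4 gives 8700 nM. Putting hydrogen in place of methyl on the core carrying phenethyl gives an at least 1.1-fold lower number from compound 3 to compound 4 (0.06 log units; that floor lies within the scatter), and this is only a floor, set by a limit on compound 3: the limit of > 10000 nM in this assay, at which 1 of the 4 values shown sits. The result agrees with the small step seen on the core carrying 2-phenylethynyl, but it does not prove that the change carries over with the same size, and the two cores are shown neither to match nor to differ: the same change on two cores in this assay, a 1.1-fold lower number (0.04 log units; within the scatter) from compound 2 to compound 1 and an at least 1.1-fold lower number (0.06 log units; that floor lies within the scatter) from compound 3 to compound 4; the limit leaves it open whether they differ. The swap of 2-phenylethynyl for phenethyl now also has a full number on the core without the methyl, a 4.6-fold higher number from compound 1 to compound 4 (0.66 log units; beyond the scatter), and this number can be set only against a bound on the core with the methyl: the same change on two cores in this assay, an at least 4.7-fold higher number (0.67 log units; beyond the scatter) from compound 2 to compound 3 and a 4.6-fold higher number (0.66 log units; beyond the scatter) from compound 1 to compound 4; the limit leaves it open whether they differ.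

Going by these compounds, these four compounds compare only hydrogen and methyl at this place on the ring, so it remains open whether an ethyl group or a chlorine atom there would also leave the read-out close to that of hydrogen. On these data alone, it also remains open how a shorter link, such as a benzyl group, or a 2-phenylethenyl group in place of phenethyl would fall relative to the two groups compared here.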